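The source may hold more compounds than are shown below. What is called first, only, known or untested is meant among the compounds shown, and "the series" means these compounds.

Measured so far in an ADME assay on microsomes from liver (Rattus norvegicus) for metabolic stability, read by LC-MS, in the presence of a further agent that is not named here; on this read-out lower numbers stand for slow clearance and higher numbers for fast clearance:
- compound 1 `Cc1ncc(C)n2nc(-c3ccc4nc(-c5ccccc5)[nH]c4c3)nc12`: compound 1 gives 27.4 mL.min-1.g-1
- compound 2 `Cc1nc(-c2ccc3nc(-c4ccccc4)[nH]c3c2)nc2ccccc12`: compound 2 gives > 450 mL.min-1.g-1, which is a limit of the assay and not a number

Of the two compounds measured in this assay, compound 1 is the only one that stands at a number. Compound 2 sits at the limit of > 450 mL.min-1.g-1 in this assay, at which 1 of the 2 values shown sits, and gives no number of its own. For the measured compounds named here, no two measured compounds differ in a single place, so no measured step exists on which to build.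

Compound 3 `Cc1ncc(C)n2nc(-c3ccc4nc(-c5ccco5)[nH]c4c3)nc12` has not yet been measured in this assay. It differs from compound 1 in one place: furan-2-yl in place of phenyl on an aromatic carbon. Going by the values given here, with no measured step to lean on, the expectation rests on compound 1 alone. The step from compound 1 to compound 3 is expected to be small, a 1.6-fold higher number from compound 1 to compound 3 (0.22 log units; within the scatter), pointing toward faster clearance but not clearly beyond the usual scatter of repeated measurements. Compound 3 is accordingly expected to give about 45 mL.min-1.g-1, with a likely range from 15 mL.min-1.g-1 to 150 mL.min-1.g-1.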

Compound 3, intrinsic clearance in microsomes: 26.3 mL.min-1.g-1
The estimate for compound 3 lay 1.7-fold (0.23 log units) above the measured number; the range from low to high includes it.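

In this assay, for the compounds shown here, the first step that can be read at this place, an aromatic carbon between two ring nitrogen atoms, is furan-2-yl in place of phenyl: a 1.0-fold lower number from compound 1 to compound 3 (0.02 log units; within the scatter). Compound 1 and compound 3 therefore cannot be told apart on this read-out, and a five-membered aromatic ring with 1 hetero atom serves here as well as a six-membered aromatic ring of carbon only, although the hydrogen-bond acceptor count differs between the two groups. Nothing measured among these compounds accounts for this result.

On these data alone, this one exchange of one aromatic ring for another says nothing about how far the place stays indifferent, and whether an amine such as morpholine, a carboxylic acid or a longer alkyl chain on the same carbon would keep the number close to that of compound 1 remains open. As far as these compounds go, compound 2 gives > 450 mL.min-1.g-1, which is a limit of the assay and not a number, so the part played by the shared core in this read-out also remains open.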